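The source may hold more compounds than are shown below. What is called first, only, known or untested is meant among the compounds shown, and "the series" means these compounds.

Measured compounds:
- compound 1, `CS(=O)(=O)Nc1ccc(-c2nc3cc(NS(=O)(=O)c4ccc(Cl)s4)ccc3o2)cc1`: 43000 nM in an assay on cells for inhibition of HSP60/HSP10 (Homo sapiens), with a stated time of 60 min; a higher number here means a weaker inhibitor, a lower number a stronger inhibitor
- compound 2, `C=Cc1ccc(S(=O)(=O)Nc2ccc3oc(-c4ccccc4)nc3c2)cc1`: > 100000 nM in this assay; this is a limit of the assay, not a number.
- compound 3, `O=S(=O)(Nc1ccc2oc(-c3ccccc3)nc2c1)c1ccc(F)c(C(F)(F)F)c1`: 69000 nM in this assay

Compound 2 stands at the limit of this assay, one of the values of the series that sits there (the limit of > 100000 nM in this assay, at which 1 of the 3 values shown sits). Among the compounds with values here, compound 1 and compound 3 each gave a number; both are weak, and no two measured compounds differ in only one place, so no measured step is available.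

Compound 4, `O=S(=O)(Nc1ccc2oc(-c3ccccc3)nc2c1)c1ccccc1Cl`, has not been measured. It differs from compound 2 in one place: 2-chlorophenyl in place of 4-vinylphenyl on a sulfonyl sulfur. Within the data shown here, no measured step covers this change, so the expectation rests on the series as a whole, which has stayed weak throughout. Compound 4 is expected to give 70000 nM, within 25000 nM to 150000 nM, with a real chance of another limit. The step from compound 2 to compound 4 is estimated as an at least 1.4-fold lower number from compound 2 to compound 4 (0.15 log units; that floor lies within the scatter), a small gain at most, but measured from a limit it may be nothing beyond the scatter.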

Compound 4, half-maximal inhibitory concentration: > 100000 nM
Compound 4 was reported as a limit; the forecaster's own chance of this, stated with the estimate: 40%; middle value at least 1.4-fold (0.15 log units) from the limit.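

Compound 4, like compound 2, sits at a limit of this assay, so the step between these two compounds cannot be read: the limit of > 100000 nM in this assay, at which 2 of the 4 values shown sit.

The compounds shown leave open whether 2-chlorophenyl and 4-vinylphenyl on a sulfonyl sulfur differ at all in this assay.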